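The source may hold more compounds than are shown below. What is called first, only, known or untested is meant among the compounds shown, and "the series" means these compounds.

Measured so far in a functional assay on HL-60 cells (Homo sapiens) for inhibition, read by CCK-8 assay, with a stated time of 48 h, tested at 20 uM; on this read-out lower numbers stand for less inhibition of growth and higher numbers for more inhibition of growth at the one concentration tested:
compound 1, `N#C/C(=C\c1ccccc1OS(=O)(=O)c1ccc([N+](=O)[O-])cc1)C(=O)Nc1nnc(Cc2cccc3ccccc23)s1`: 18%
compound 2, `N#C/C(=C\c1ccccc1OS(=O)(=O)c1ccccc1[N+](=O)[O-])C(=O)Nc1nnc(Cc2cccc3ccccc23)s1`: 23%
compound 3, `N#C/C(=C\c1ccccc1OS(=O)(=O)c1ccc([N+](=O)[O-])cc1)C(=O)Nc1nnc(Cc2ccc(F)cc2)s1`: 18%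

All three share one core and differ only at two spots. Compound 2 differs from compound 1 by 2-nitrophenyl in place of 4-nitrophenyl on a sulfonyl sulfur, and this gave a number 5 percentage points higher from compound 1 to compound 2 (within the scatter). Compound 3 differs from compound 1 by 4-fluorophenyl in place of naphthalen-1-yl on a saturated chain carbon bound to an aromatic carbon, and here the result was no change at the digits printed from compound 1 to compound 3 (within the scatter), so compound 3 and compound 1 stand level in this assay.

Compound 4, `N#C/C(=C\c1ccccc1OS(=O)(=O)c1ccccc1[N+](=O)[O-])C(=O)Nc1nnc(Cc2ccc(F)cc2)s1`, has not yet been measured. It differs from compound 3 by 2-nitrophenyl in place of 4-nitrophenyl on a sulfonyl sulfur, the same change made between compound 1 and compound 2, at the same place. Since that step was a number 5 percentage points higher from compound 1 to compound 2 (within the scatter), a step of similar size is expected here, namely a number 5 percentage points higher from compound 3 to compound 4 (within the scatter). Compound 4 is therefore expected to give about 23% in this assay, most likely between 12% and 34%.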

Compound 4, percent growth inhibition at one concentration: 35%
Compound 4: middle estimate off by 12 percentage points, on the low side, outside the stated range (above it).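

In this assay, 2-nitrophenyl in place of 4-nitrophenyl on the sulfonyl sulfur gave a number 17 percentage points higher from compound 3 to compound 4 (beyond the scatter), yet this step cannot be told apart from the one on the other core: the same change on two cores in this assay, a number 5 percentage points higher (within the scatter) from compound 1 to compound 2 and a number 17 percentage points higher (beyond the scatter) from compound 3 to compound 4, 12 percentage points apart, within the scatter of two such steps. Likewise, 4-fluorophenyl in place of naphthalen-1-yl gave a number 12 percentage points higher from compound 2 to compound 4 (beyond the scatter), and this step also cannot be told apart from its earlier counterpart: the same change on two cores in this assay, no change at the digits printed (within the scatter) from compound 1 to compound 3 and a number 12 percentage points higher (beyond the scatter) from compound 2 to compound 4, 12 percentage points apart, within the scatter of two such steps. Each change is therefore consistent with carrying over from one core to the other, but a single pair of steps per change does not show that the steps are truly equal or that this would hold across the series.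

The compounds shown leave open whether the same holds for other groups on the sulfonyl sulfur, such as a plain phenyl or a methyl. As far as these compounds go, it is also open whether it holds with a cyclohexyl in place of 4-fluorophenyl.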